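Notes on the series: the step from compound 3 to compound 4

The source may hold more compounds than are shown below. What is called first, only, known or untested is meant among the compounds shown, and "the series" means these compounds.

In an in vitro ADME assay on microsomes (Rattus norvegicus) for metabolic stability (a higher number here means that the compound lasts longer, a lower number that the compound disappears faster), compound 3 `Cc1c2c(n3c1CCN(C(=O)C(C)(C)N)C[C@@H](C)[C@H](C)Nc1cc-3ccc1C(N)=O)CC(C)(C)CC2=O` gives > 0.5 h as a limit and not a number. Compound 1 `Cc1c2c(n3c1CCCNC[C@H](C)Nc1cc-3ccc1C(N)=O)CC(C)(C)CC2=O` gives > 0.5 h as a limit too. Compound 2 `Cc1c2c(n3c1CCN(C(=O)[C@@H](N)C(C)C)C[C@@H](C)[C@H](C)Nc1cc-3ccc1C(N)=O)CC(C)(C)CC2=O` gives 0.217 h as a measured number. The series therefore has the limit of > 0.5 h in this assay, at which 2 of the 3 values shown sit, as its most common reading.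

The structural change to compound 4 `Cc1c2c(n3c1CCN(C(=O)[C@@H](O)C(C)C)C[C@@H](C)[C@H](C)Nc1cc-3ccc1C(N)=O)CC(C)(C)CC2=O` is 1-hydroxy-2-methylpropyl in place of 1-amino-1-methylethyl on a carbonyl carbon in which 1-hydroxy-2-methylpropyl takes the place of 1-amino-1-methylethyl on a carbonyl carbon. Within the data shown here, the one measured step at this place is an at least 2.3-fold higher number from compound 2 to compound 3 (0.36 log units; beyond the scatter) with 1-amino-1-methylethyl in place of 1-amino-2-methylpropyl. The entering group of compound 4 shares its 2-methylpropyl ending with the group that left in an at least 2.3-fold higher number from compound 2 to compound 3 (0.36 log units; beyond the scatter) so a move of about that size in the opposite direction is expected in this assay for now. Among the measured compounds shown here, no measured step covers hydroxy in place of amino, so the range stays wide. The expected change is an at least 2.0-fold lower number from compound 3 to compound 4 (0.30 log units; that floor lies within the scatter) toward a lower number. Compound 4 is estimated at 0.25 h with an expected range of 0.12 h to 0.5 h in this assay.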

Compound 4, half-life: 0.317 h
Compound 4: the middle estimate sits 1.3-fold (0.10 log units) below what was measured; the measured number falls inside the stated range.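

In this assay the exchange of 1-amino-2-methylpropyl for 1-hydroxy-2-methylpropyl now has a reading of its own: a 1.5-fold higher number from compound 2 to compound 4 (0.16 log units; within the scatter), so the values shown do not tell hydroxy and amino apart on this chain carbon. The change from 1-amino-1-methylethyl to 1-hydroxy-2-methylpropyl on the carbonyl carbon reads an at least 1.5-fold lower number from compound 3 to compound 4 (0.19 log units; that floor lies within the scatter), and with that floor inside the scatter, this step alone does not establish a real drop. Compound 3 remains a limit, and that reading is still the most common in the series, though it now holds a smaller share of the values: the limit of > 0.5 h in this assay, at which 2 of the 4 values shown sit.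

Still open, as far as these compounds go, is how 1-hydroxy-1-methylethyl on the same carbonyl carbon would read in this assay, a group that would separate the effect of swapping amino for hydroxy from the difference between 1-methylethyl and 2-methylpropyl. From the compounds shown here alone, the full size of the step from compound 3 also remains unknown, as does the reading of a methoxy group on this chain carbon or of a longer chain in place of the 2-methylpropyl ending.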